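Ester to acid, repeated on a second core

The source may report more compounds than this note shows. Statements on the series, on what has been measured and on what is new or still open speak of the compounds shown alone.

Compound 2 `CCOC(=O)/C(O)=C/C(=O)c1cn(Cc2ccc(F)cc2)c2cccc(OC)c12` and compound 1 `COc1cccc2c1c(C(=O)/C=C(\O)C(=O)O)cn2Cc1ccc(F)cc1` share one core and differ in a single place (hydrogen in place of ethyl on an oxygen next to a carbonyl group). In an ADME assay on MT4 cells (Homo sapiens) for cytotoxicity, read by MTT assay (a lower number here means that less compound is tolerated, a higher number that more compound is tolerated), compound 2 gives 74000 nM, while compound 1 gives 41100 nM; the step of a 1.8-fold lower number from compound 2 to compound 1 (0.26 log units; within the scatter) stays within the usual scatter. Compound 3 `CCOC(=O)/C(O)=C/C(=O)c1cn(Cc2ccc(F)cc2)c2cc(OC)ccc12` carries the same ethyl ester on a core built from the same atoms joined differently; the difference between the two cores is not broken down here. In this assay compound 3 gives 100000 nM, a number whose gap to compound 2 is within the scatter and whose gap to compound 1 lies beyond it. Compound 4 `COc1ccc2c(C(=O)/C=C(\O)C(=O)O)cn(Cc3ccc(F)cc3)c2c1` differs from compound 3 in one place (hydrogen in place of ethyl on an oxygen next to a carbonyl group), the same change as from compound 2 to compound 1 at a place described in the same words. Because the earlier step of a 1.8-fold lower number from compound 2 to compound 1 (0.26 log units; within the scatter) was small, a similar step is expected here, a 1.7-fold lower number from compound 3 to compound 4 (0.22 log units; within the scatter). Compound 4 is estimated at 60000 nM, within a range from 30000 nM to 120000 nM.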

Compound 4, half-maximal cytotoxic concentration: 66000 nM
The estimate for compound 4 lay 1.1-fold (0.04 log units) below the measured number; the range from low to high includes it.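

In this assay, exchanging ethyl for hydrogen on the second core, which turns ethoxycarbonyl into carboxy, gives a 1.5-fold lower number from compound 3 to compound 4 (0.18 log units; within the scatter). Set beside the step on the first core, this step agrees with it: the same change on two cores in this assay, a 1.8-fold lower number (0.26 log units; within the scatter) from compound 2 to compound 1 and a 1.5-fold lower number (0.18 log units; within the scatter) from compound 3 to compound 4, 1.2-fold (0.07 log units) apart, within the scatter of two such steps

Within these two pairs, then, the change carries from one core to the other without a detectable difference in size, but neither step stands clear of the scatter, so the pairs show no measurable effect of the change on either core, and two cores cannot establish how it would behave on a third.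

The compounds shown hold only ethoxycarbonyl and carboxy at this place, so it remains open whether a longer chain on the same oxygen, or an amide in place of the ester, would also leave the number within the scatter. They also leave open whether the agreement between the two cores would hold for a compound carrying an amine on the core.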